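Swapping dimethoxyphenyl for dichlorophenyl: cytotoxicity expectations

The source may report more compounds than this note shows. Statements on the series, on what has been measured and on what is new or still open speak of the compounds shown alone.

The series shares one core, seen in compound 1 `CC(C)N(Cc1cccc(OCCCCCC(=O)O)c1)C(=O)c1ccc(-c2cccc(N(C)C)c2)cc1`, compound 2 `CC(C)N(Cc1cccc(OCCCCCC(=O)O)c1)C(=O)c1ccc(-c2ccco2)cc1` and compound 3 `COc1cc(OC)cc(-c2ccc(C(=O)N(Cc3cccc(OCCCCCC(=O)O)c3)C(C)C)cc2)c1`, and the members differ only in the group attached on an aromatic carbon of that core. In an ADME assay on HEK293 cells (Homo sapiens) for cytotoxicity, read by CellTiter-Glo and resazurin assay, with a stated time of 72 h (a lower number here means that less compound is needed, a higher number that more compound is needed for the effect), compound 1 reaches only a limit of > 26000 nM. Compound 2 likewise gives a limit of > 26000 nM in this assay. Compound 3 also stands at a limit, > 26000 nM, in this assay, so no number sets it apart from the other two. The three pairwise comparisons, a step that the two limits leave unreadable from compound 1 to compound 2, a step that the two limits leave unreadable from compound 1 to compound 3 and a step that the two limits leave unreadable from compound 2 to compound 3, therefore carry no readable size, as the limit of > 26000 nM in this assay, at which 3 of the 3 values shown sit, makes plain. Compound 4 `CC(C)N(Cc1cccc(OCCCCCC(=O)O)c1)C(=O)c1ccc(-c2ccc(Cl)c(Cl)c2)cc1` is the next member: 3,4-dichlorophenyl in place of 3,5-dimethoxyphenyl on an aromatic carbon. Nothing measured shows that a change of this aryl group moves the read-out off the limit, and the three unreadable steps give no direction to project. For compound 4 the step of a number no higher from compound 3 to compound 4 (the limit leaves the size open) in this assay is expected to be none beyond the scatter. Compound 4 is therefore estimated at 26000 nM in this assay, within 13000 nM to 60000 nM, with the most likely outcome being another limit rather than a number.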

Compound 4, half-maximal effective concentration: > 26000 nM
Compound 4 gave a limit, no number; the forecaster's own chance of this, stated with the estimate: 80%; the middle value lies on the limit itself.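

Compound 4 also ends at a limit in this assay, so its steps from compound 1, compound 2 and compound 3 cannot be read, and the series stays without a number: the limit of > 26000 nM in this assay, at which 4 of the 4 values shown sit. The compounds shown leave open whether any group at this place on the shared core gives a measurable effect in this assay.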